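A few compounds are considered here, and "the series" means these few. Any claim that something is new, unique, unknown or untested is made for them only; others in the source may bear on it.

Values in a functional assay on HeLa cells (Homo sapiens) for antiproliferative activity, read by MTT assay, with a stated time of 72 h; a lower number here means a stronger inhibitor, a higher number a weaker inhibitor:
- compound 1 `Nc1nc(N)c2cc(CSC(=S)N3CCN(C4CCCCC4)CC3)ccc2n1`: 5960 nM
- compound 2 `Nc1nc(N)c2cc(CSC(=S)N3CCN(c4ccc(Cl)cc4)CC3)ccc2n1`: 6990 nM
- compound 3 `Nc1nc(N)c2cc(CSC(=S)N3CCN(c4ccc([N+](=O)[O-])cc4)CC3)ccc2n1`: 1660 nM

Compound 3 has the lowest number of the three. Next comes compound 4 `Nc1nc(N)c2cc(CSC(=S)N3CCN(c4ncccn4)CC3)ccc2n1`, with pyrimidin-2-yl in place of 4-nitrophenyl on an amine nitrogen in a ring.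

Three measured steps at this nitrogen bear on the change. Both a 3.6-fold lower number from compound 1 to compound 3 (0.56 log units; beyond the scatter) and a 4.2-fold lower number from compound 2 to compound 3 (0.62 log units; beyond the scatter) are modest, while a 1.2-fold higher number from compound 1 to compound 2 (0.07 log units; within the scatter) stays within the scatter. For the measured compounds named here, no measured compound carries a pyrimidin-2-yl group, so the estimate is loose. Compound 4 is expected to drift back toward compound 1 and compound 2.

The expected step in this assay is modest and toward a higher number: a 2.1-fold higher number from compound 3 to compound 4 (0.32 log units; beyond the scatter).

For compound 4 the estimated value is 3500 nM, with an expected range of 1300 nM to 9000 nM.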

Compound 4, half-maximal inhibitory concentration: 4360 nM
For compound 4 the middle estimate is 1.2-fold (0.10 log units) below the measured one; the range from low to high includes it.
By their numbers in this assay, from the lowest: compound 3; then compounds 4, 1 and 2 (each within the scatter of the next).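

In this assay, pyrimidin-2-yl on the ring nitrogen does not keep the lower number of the 4-nitrophenyl group, with a 2.6-fold higher number from compound 3 to compound 4 (0.42 log units; beyond the scatter) beyond the scatter. Against the other two groups, a 1.6-fold lower number from compound 2 to compound 4 (0.20 log units; within the scatter) and a 1.4-fold lower number from compound 1 to compound 4 (0.14 log units; within the scatter) both stay within the scatter, so pyrimidin-2-yl, 4-chlorophenyl and cyclohexyl cannot be separated here and only compound 3 stands apart. Nothing available explains why compound 3 stands apart.

Still open, from the compounds shown here alone, is whether the nitro group itself sets compound 3 apart, which a nitrile or an amine on the same phenyl ring would test.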